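Chloro for fluoro on the aryl ring of a pyrrolidine amide

This account rests on a few compounds, and the source may have more. Where it says the series, first, only, none or still open, it means among the compounds named here.

Measured compounds:
- Compound 1, `O=C(CCCCCCc1ccccc1)N1CCCC1`: 12900 nM
- Compound 2, `O=C(CCCCCCc1cccc(F)c1)N1CCCC1`: 7300 nM

For the measured compounds named here, compound 2 holds the lower of the two numbers so far in an assay on HEK293 cells for inhibition of N-acylethanolamine-hydrolyzing acid amidase (Rattus norvegicus), read by LC-MS, with a stated time of 30 min; a higher number here means a weaker inhibitor, a lower number a stronger inhibitor. Going by the values given here, its only neighbour on record is compound 1, and the single step measured, a 1.8-fold lower number from compound 1 to compound 2 (0.25 log units; within the scatter), lies within the scatter, so compound 2 cannot be called the stronger inhibitor of the two on this evidence.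

Compound 3, `O=C(CCCCCCc1cccc(Cl)c1)N1CCCC1`, has not yet been measured. It differs from compound 2 in one place: chloro in place of fluoro on an aromatic carbon. Among the compounds with values here, the only measured step that touches this aromatic carbon is the one from hydrogen to fluoro, which did not move the number beyond the scatter. There is no measured exchange of one halogen for another in this set, so the expectation for compound 3 rests on that single small step and on the closeness of the two structures.

Compound 3 is therefore expected to give a number near that of compound 2 in this assay, with at most a modest lowering, a step estimated as a 1.5-fold lower number from compound 2 to compound 3 (0.16 log units; within the scatter). The estimate for compound 3 is 5000 nM, within a range from 1500 nM to 15000 nM.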

Compound 3, half-maximal inhibitory concentration: 3700 nM
Compound 3: middle estimate off by 1.4-fold (0.13 log units), on the high side; measured number inside the range.
By their numbers in this assay, from the lowest: compounds 3, 2 and 1 (each within the scatter of the next, the first and the last beyond it).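

In this assay, for the compounds shown here, the exchange of fluoro for chloro on this aromatic carbon, meta to a large group, gives the first reading of one halogen against another (a 2.0-fold lower number from compound 2 to compound 3 (0.30 log units; within the scatter)), and that step lies within the scatter, so this change does not separate compound 3 from compound 2. The comparison with the unsubstituted compound shows something the fluoro step could not: a single halogen at this position can move the number beyond the scatter, though only modestly (a 3.5-fold lower number from compound 1 to compound 3 (0.54 log units; beyond the scatter)), which makes chloro the first substituent here with a step that can be read as real. No measurement on hand offers a reason for either step.

The compounds shown leave open whether a bromo, methyl, methoxy or trifluoromethyl group on the same aromatic carbon would carry the number further down in the same direction or would stay within the scatter of compound 3. They also leave open whether the modest gain from chloro would persist on a shorter or longer chain, or with an amine or a carboxylic acid in place of the halogen.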